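From 4-isopropylpiperazin-1-yl to 4-ethylpiperazin-1-yl: one small step

The source may hold more compounds than are shown below. What is called first, only, known or untested is meant among the compounds shown, and "the series" means these compounds.

- compound 1 `CN1CCC2(CC1)CC(S(=O)(=O)c1c(Cl)ccc(NC(=O)Nc3cccc(F)c3Cl)c1O)C2` gives 1390 ng.h/mL
- compound 2 `C[C@@H]1CN(S(=O)(=O)c2c(Cl)ccc(NC(=O)Nc3cccc(F)c3Cl)c2O)C[C@H](C)O1` gives 279 ng.h/mL
- compound 3 `CC(C)N1CCN(S(=O)(=O)c2c(Cl)ccc(NC(=O)Nc3cccc(F)c3Cl)c2O)CC1` gives 52.9 ng.h/mL

In an ADME assay on the whole organism (blood, Mus musculus, strain C57BL/6) for pharmacokinetics, read by HPLC, with a stated time of 4 h, at a dose of 2 mg/kg by the intraperitoneal route (on this read-out lower numbers stand for lower exposure and higher numbers for higher exposure at the dose given), compound 3 has the lowest number of the three. The steps leading to it are a 5.3-fold lower number from compound 2 to compound 3 (0.72 log units; beyond the scatter) and a 26-fold lower number from compound 1 to compound 3 (1.42 log units; beyond the scatter), and both lie beyond the usual scatter.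

The next compound to be measured is compound 4 `CCN1CCN(S(=O)(=O)c2c(Cl)ccc(NC(=O)Nc3cccc(F)c3Cl)c2O)CC1`, and the change is small: hydrogen in place of methyl on a saturated chain carbon bound to an amine nitrogen in a ring and a saturated chain carbon. In words, this is hydrogen in place of methyl on a saturated chain carbon bound to an amine nitrogen in a ring and a saturated chain carbon, so isopropyl becomes ethyl.

Among the compounds with values here, no measured pair isolates a change of this kind. The measured steps, such as a 5.0-fold lower number from compound 1 to compound 2 (0.70 log units; beyond the scatter), each replace a whole group on the sulfonyl sulfur, so they offer only a rough upper guide. With far less of the structure altered here, no step beyond the scatter is expected, and these data do not settle a direction. The estimate therefore means a 1.2-fold higher number from compound 3 to compound 4 (0.09 log units; within the scatter), which is expected to stay within the usual scatter. For compound 4 the estimated value is 65 ng.h/mL, with an expected range from 25 ng.h/mL to 170 ng.h/mL.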

Compound 4, area under the concentration-time curve: 189 ng.h/mL
Beside the measured number, compound 4's estimate is 2.9-fold (0.46 log units) below it; the measured number lies above the stated range.
By their numbers in this assay, from the lowest: compound 3; then compounds 4 and 2 (each within the scatter of the next); then compound 1.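

Removing one methyl, so that isopropyl becomes ethyl, gives a 3.6-fold higher number from compound 3 to compound 4 (0.55 log units; beyond the scatter) in this assay, which shows that even a change this small, on a saturated chain carbon bound to an amine nitrogen in a ring, can shift exposure by more than the usual scatter. With 4-ethylpiperazin-1-yl in place, a 1.5-fold lower number from compound 2 to compound 4 (0.17 log units; within the scatter) puts this compound level with the 2,6-dimethylmorpholin-4-yl compound, whereas a 7.4-fold lower number from compound 1 to compound 4 (0.87 log units; beyond the scatter) shows that the group on the sulfonyl sulfur of compound 1 still gives clearly higher exposure than either piperazine. Nothing available explains why losing this methyl raises the number, so the shift stands as an observation without a known cause.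

As far as these compounds go, all of this rests on a single pair of compounds that differ at this position, so it remains open whether exposure would keep climbing as the group on the piperazine shrinks further, to a methyl or to a plain hydrogen. From the compounds shown here alone, it is equally open how a longer chain, such as propyl, or a chain ending in a hydroxyl group would behave in this place.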